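Dechlorination step traced from compound 2 to compound 4

The compounds below may be only part of what the source reports. "The series", "measured", "known", "first", "only" and "open" are said of these compounds alone.

Three compounds have been measured in a functional assay on T47D cells (Homo sapiens) for cytotoxicity, read by sulforhodamine B assay, with a stated time of 48 h; on this read-out lower numbers stand for stronger inhibition of growth and higher numbers for weaker inhibition of growth:

compound 1, `ClCc1cccc(Cn2cnc3c(Cl)ncnc32)c1`, compound 1 gives 3020 nM
compound 2, `ClCc1ccc(Cn2cnc3nc(Cl)nc(Cl)c32)cc1`, compound 2 gives 10200 nM
compound 3, `ClCc1cccc(Cn2cnc3c(Cl)nc(Cl)nc32)c1`, compound 3 gives 1950 nM

Compound 3 and compound 1 differ in one place, (hydrogen in place of chloro on an aromatic carbon), and the step that this change made is a 1.5-fold higher number from compound 3 to compound 1 (0.19 log units; within the scatter). Compound 2 and compound 3 are built from the same atoms joined differently; the difference between the two cores is not broken down here. Compound 2 stands highest of the three numbers, beyond the scatter from both compound 1 and compound 3, so among the measured compounds it shows the weakest inhibition of growth.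

Compound 4, `ClCc1ccc(Cn2cnc3ncnc(Cl)c32)cc1`, is not yet measured. It differs from compound 2 by hydrogen in place of chloro on an aromatic carbon. The place of this change reads word for word as the place of the change from compound 3 to compound 1, so the two are the same change. Within the data shown here, on the strength of the one measured step, a 1.5-fold higher number from compound 3 to compound 1 (0.19 log units; within the scatter), the expected step in this assay is a 1.3-fold higher number from compound 2 to compound 4 (0.11 log units; within the scatter), a small rise in the number that stays within the scatter. The expectation rests on a single pair and on the assumption that the change behaves alike on the core of compound 2. Compound 4 is therefore estimated at 13000 nM, between 5000 nM and 35000 nM.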

Compound 4, concentration for 50% growth inhibition: 1280 nM
Estimate against measurement, compound 4: 10-fold (1.01 log units) above; measured number below the stated range.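

In this assay, hydrogen in place of chloro on an aromatic carbon gives an 8.0-fold lower number from compound 2 to compound 4 (0.90 log units; beyond the scatter), and this step does not carry over between the two cores: the same change on two cores in this assay, a 1.5-fold higher number (0.19 log units; within the scatter) from compound 3 to compound 1 and an 8.0-fold lower number (0.90 log units; beyond the scatter) from compound 2 to compound 4, 12-fold (1.09 log units) apart, beyond the scatter of two such steps

The replacement therefore goes with stronger inhibition of growth on the core of compound 2, while on the core of compound 3 the step stays within the scatter, so a step read on one core in this series is no safe guide to the other. Resting on only two matched pairs, the comparison shows that the outcome depends on the core, but it does not show which feature of the core is responsible, nor which of the two steps would be the more typical on any further core.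

The compounds shown leave open how an amine or a methoxy group on the same aromatic carbon would behave on either core, and whether such groups would also diverge between the two. Also open, from the compounds shown here alone, is what the chloromethyl group contributes to growth inhibition, a question that a methyl or hydroxymethyl group in its place would address.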